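Ethoxycarbonyl to acetyl in a small series

A few compounds are considered here, and "the series" means these few. Any claim that something is new, unique, unknown or untested is made for them only; others in the source may bear on it.

Measured in an ADME assay on L929 cells (Mus musculus) for cytotoxicity, with a stated time of 72 h; on this read-out higher numbers stand for weaker inhibition and lower numbers for stronger inhibition:
compound 1 `CCOC(=O)C(C)Oc1ccc2c(c1)B(O)OC2`: > 10 ug/mL
compound 2 `CCOC(=O)C(CC)Oc1ccc2c(c1)B(O)OC2`: > 10 ug/mL

Compound 2 gives > 10 ug/mL, which is a limit of the assay and not a number. Compound 1 gives > 10 ug/mL, again a limit. Going by the values given here, the series so far therefore offers only (the limit of > 10 ug/mL in this assay, at which 2 of the 2 values shown sit).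

Compound 3 `CCC(Oc1ccc2c(c1)B(O)OC2)C(C)=O` differs from compound 2 as follows: methyl in place of ethoxy on a carbonyl carbon. In words, this is methyl in place of ethoxy on a carbonyl carbon, or ethoxycarbonyl to acetyl.

Among the compounds with values here, the only measured step, a step that the two limits leave unreadable from compound 1 to compound 2, is methyl in place of hydrogen on a saturated chain carbon. It does not involve the group on the carbonyl carbon, and it has no readable size, so it gives no measure for this change. No step beyond the scatter is expected in this assay, and no direction can be assigned. This expectation rests on compound 2, whose > 10 ug/mL is a limit. The expected step is a step that the limit leaves unreadable from compound 2 to compound 3. A report as a limit is also likely. For compound 3 the estimated value is 20 ug/mL, with an expected range from 8 ug/mL to 60 ug/mL.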

Compound 3, half-maximal inhibitory concentration: > 10 ug/mL
Compound 3: only a limit was reported; the forecaster's own chance of this, stated with the estimate: 75%; the middle value lies beyond the limit too.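

In this assay compound 3 gives > 10 ug/mL, which is a limit of the assay and not a number. No new step can be read between compound 2 and compound 3, and the series stays at a single limit: the limit of > 10 ug/mL in this assay, at which 3 of the 3 values shown sit.

The compounds shown leave open whether ethoxycarbonyl and acetyl differ at all in this assay.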